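The compounds below may be only part of what the source reports. "The series", "measured", "known", "first", "only" and "open" are said of these compounds alone.

The measured compounds:

Compound 1, `COc1cc(/C=C/C(=O)C2=C(/C=C/c3ccc(O)c(OC)c3)NC(=O)NC2c2c(Cl)cccc2Cl)ccc1O`: in a functional assay, with a stated time of 20 min, tested at 20 uM (on this read-out lower numbers stand for a weaker effect and higher numbers for a stronger effect at the one concentration tested), compound 1 gives 33%.
Compound 2, `COc1cc(/C=C/C(=O)C2=C(/C=C/c3ccc(O)c(OC)c3)NC(=O)NC2c2ccccc2Cl)ccc1O`: in this assay compound 2 gives 38.7%.
Compound 3, `COc1cc(/C=C/C(=O)C2=C(/C=C/c3ccc(O)c(OC)c3)NC(=S)NC2c2c(Cl)cccc2Cl)ccc1O`: in this assay compound 3 gives 33.9%.

Compound 2 differs from compound 1 by hydrogen in place of chloro on an aromatic carbon. In this assay this change made a number 5.7 percentage points higher from compound 1 to compound 2 (within the scatter). The difference between the cores of compound 1 and compound 3 is not broken down here; their two values lie within the scatter of each other.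

Compound 4, `COc1cc(/C=C/C(=O)C2=C(/C=C/c3ccc(O)c(OC)c3)NC(=S)NC2c2ccccc2Cl)ccc1O`, has not yet been measured. Within the data shown here, it differs from compound 3 by hydrogen in place of chloro on an aromatic carbon, the same change at the same place as the one from compound 1 to compound 2. The step in this assay is expected to be a number 5.1 percentage points higher from compound 3 to compound 4 (within the scatter), of a similar small size, because a number 5.7 percentage points higher from compound 1 to compound 2 (within the scatter) stayed within the scatter. Compound 4 is therefore estimated at 39%, most likely between 29% and 49%.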

Compound 4, a percentage reported as activity, at one concentration (the size of the read-out at that concentration, not a potency): 39.2%
Compound 4: the middle estimate sits 0.2 percentage points below what was measured; the range from low to high includes it.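

In this assay, going from 2,6-dichlorophenyl to 2-chlorophenyl on the core of compound 3 gave a number 5.3 percentage points higher from compound 3 to compound 4 (within the scatter), and the change read alike on both cores: the same change on two cores in this assay, a number 5.7 percentage points higher (within the scatter) from compound 1 to compound 2 and a number 5.3 percentage points higher (within the scatter) from compound 3 to compound 4, 0.4 percentage points apart, within the scatter of two such steps

This shows that, across these two cores, the change carried over without a difference that can be told from the scatter. It does not show that the change has a real effect on either core, as each step lies within the scatter, and two cores cannot speak for the whole series.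

The compounds shown leave open how this aromatic ring would read with a methoxy group, a nitro group or an amine in place of chloro. They also leave open whether a core other than these two would give a similar step.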